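Growing the Amide Aryl Ring: Compound 2 to Compound 4

The source may report more compounds than this note shows. Statements on the series, on what has been measured and on what is new or still open speak of the compounds shown alone.

Three boron-containing amides share one core and differ only in the group attached to the amide nitrogen. Compound 1 `O=C(CCc1cccc2c1B(O)OC2)NC1CCCCC1` carries a cyclohexyl group; in a functional assay on SK-OV-3 cells (Homo sapiens) for antiproliferative activity, read by MTT assay, with a stated time of 72 h (on this read-out higher numbers stand for weaker inhibition and lower numbers for stronger inhibition), compound 1 reaches only the limit of > 100000 nM, so no number is known for it. Compound 2 `O=C(CCc1cccc2c1B(O)OC2)Nc1ccccc1` carries a phenyl group, and in this assay compound 2 gives 200 nM, the lowest of the two measured numbers. Compound 3 `O=C(CCc1cccc2c1B(O)OC2)Nc1ccc(Br)cc1` carries a 4-bromophenyl group, and in this assay compound 3 gives 9200 nM. The steps between them run an at least 500-fold lower number from compound 1 to compound 2 (2.69 log units; beyond the scatter), an at least 10-fold lower number from compound 1 to compound 3 (1.03 log units; beyond the scatter) and a 46-fold higher number from compound 2 to compound 3 (1.66 log units; beyond the scatter).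

Compound 4 `O=C(CCc1cccc2c1B(O)OC2)Nc1cccc(-c2cccc(Cl)c2)c1` differs from compound 2 by 3-chlorophenyl in place of hydrogen on an aromatic carbon. For the measured compounds named here, only the step from compound 2 to compound 3 bears on this change, since both add a group to the phenyl ring, and that step was large and toward weaker inhibition. The group added here is larger and sits at another place, so the size is uncertain, but a weakening step is expected. For compound 4 the expected step is a 10-fold higher number from compound 2 to compound 4 (1.00 log units; beyond the scatter), giving an estimate of 2000 nM with a range from 300 nM to 20000 nM.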

Compound 4, half-maximal inhibitory concentration: 300 nM
Beside the measured number, compound 4's estimate is 6.7-fold (0.82 log units) above it; the measured number falls inside the stated range.
By their numbers in this assay, from the lowest: compounds 2 and 4 (each within the scatter of the next); then compound 3. At a limit, above all of these: compound 1.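

In this assay the step is a 1.5-fold higher number from compound 2 to compound 4 (0.18 log units; within the scatter), so compound 2 and compound 4 cannot be told apart, even though the new group brings a whole extra six-membered aromatic ring. The position is therefore open to a large 3-chlorophenyl group, on an aromatic carbon meta to a large group, without a step beyond the scatter. The earlier compounds shown here offered only a 46-fold higher number from compound 2 to compound 3 (1.66 log units; beyond the scatter) as a change on this phenyl ring, so a weakening step does not follow every addition to the ring, and compound 4 goes against any such rule.

From the compounds shown here alone, whether an amine, a carboxylic acid or a single chlorine atom on this same carbon would also leave the number within the scatter of compound 2 stays open. No measurement shown here bears on why the large 3-chlorophenyl group is carried this way.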